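This account rests on a few compounds, and the source may have more. Where it says the series, first, only, none or still open, it means among the compounds named here.

Of the compounds shown here, three sharing a trimethoxyphenyl group have been tested in a functional assay on BGC-823 cells (Homo sapiens) for antiproliferative activity, read by MTT assay, tested at 5 uM; on this read-out lower numbers stand for a weaker effect and higher numbers for a stronger effect at the one concentration tested. Compound 1 `COc1cc(C2=NN(C(C)=O)C(c3cc(Cl)cc(Cl)c3)O2)cc(OC)c1OC` gives 6.6% in this assay. Compound 2 `COc1cccc(/C=N/NC(=O)c2cc(OC)c(OC)c(OC)c2)c1OC` gives 14.2%, and compound 3 `COc1cc(/C=N/NC(=O)c2cc(OC)c(OC)c(OC)c2)cc(OC)c1OC` gives 22.9%. Compound 1 holds the lowest of the three numbers: the value of compound 2 lies within the usual scatter of it, so no real difference can be claimed between the two, while the value of compound 3 lies beyond that scatter.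

Compound 4 `COc1cc(C2=NN(C(C)=O)C(c3ccc(F)c(F)c3)O2)cc(OC)c1OC` is still to be measured in this assay. It differs from compound 1 in one place: 3,4-difluorophenyl in place of 3,5-dichlorophenyl on a saturated ring carbon. For the measured compounds named here, no step between measured compounds tests this kind of change, so the direction is open; a step within the scatter, in either direction, is what is expected here, since all three measured values sit in the weak range of this assay.

Compound 4 is expected to give about 9%, between 0% and 25%, which is an expected step of a number 2.4 percentage points higher from compound 1 to compound 4 (within the scatter).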

Compound 4, a percentage reported as inhibition, at one concentration (the size of the read-out at that concentration, not a potency): 21.6%
Compound 4: the middle estimate sits 12.6 percentage points below what was measured; low and high end bracket the measured number.
By their numbers in this assay, from the lowest: compounds 1, 2, 4 and 3 (each within the scatter of the next, the first and the last beyond it).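

In this assay, placing 3,4-difluorophenyl where compound 1 carries 3,5-dichlorophenyl gives a number 15 percentage points higher from compound 1 to compound 4 (beyond the scatter) on the saturated ring carbon of the shared core. For the compounds shown here, this is the first measured step at this position, and it shows that the read-out responds to a change in the halogenated phenyl group there, even though the two groups have the same count of heavy atoms. Nothing measured here accounts for the step.

Going by these compounds, two things change together in this swap, the halogen and the places it occupies on the phenyl ring, so the share of each stays open. Compounds carrying 3,5-difluorophenyl or 3,4-dichlorophenyl at this position would separate the two, and an unsubstituted phenyl group would show what the halogens contribute at all.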